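Aryl sulfonamide series: meta-methoxy replacement for para-bromo

The source may report more compounds than this note shows. Statements on the series, on what has been measured and on what is new or still open speak of the compounds shown alone.

Compound 1 `Cc1cc(C)cc(NS(=O)(=O)c2ccc(N3CCNC3=O)cc2)c1` gives 82 nM in a functional assay on HT-29 cells (Homo sapiens) for antiproliferative activity, read by sulforhodamine B assay, with a stated time of 48 h; a lower number here means a stronger inhibitor, a higher number a weaker inhibitor. Compound 2 `O=C1NCCN1c1ccc(S(=O)(=O)Nc2ccc(Br)cc2)cc1` gives 300 nM, the highest of the two numbers so far, and the only shown step, a 3.7-fold higher number from compound 1 to compound 2 (0.56 log units; beyond the scatter), is the sole comparison that bears on the aryl group on the sulfonamide nitrogen. Compound 3 `COc1cccc(NS(=O)(=O)c2ccc(N3CCNC3=O)cc2)c1` carries 3-methoxyphenyl in place of 4-bromophenyl on a sulfonamide nitrogen. With a single-substituted aryl returning, a step in this assay back toward compound 1 is expected, of moderate size and in the lowering direction: a 2.0-fold lower number from compound 2 to compound 3 (0.30 log units; within the scatter). Compound 3 is thus estimated at 150 nM, within 60 nM to 400 nM.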

Compound 3, half-maximal inhibitory concentration: 120 nM
For compound 3 the middle estimate is 1.3-fold (0.10 log units) above the measured one; measured number inside the range.
By their numbers in this assay, from the lowest: compounds 1 and 3 (each within the scatter of the next); then compound 2.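

On a sulfonamide nitrogen, 3-methoxyphenyl in place of 4-bromophenyl gives a 2.5-fold lower number from compound 2 to compound 3 (0.40 log units; beyond the scatter) and shows that a singly substituted aryl group here need not sit at the number of compound 2. 3-Methoxyphenyl in place of 3,5-dimethylphenyl gives a 1.5-fold higher number from compound 1 to compound 3 (0.17 log units; within the scatter) and so does not separate these two groups. No measurement on hand accounts for either step.

The compounds shown change both substituent and ring position together, so neither can be credited alone. As far as these compounds go, whether an amine, a carboxylic acid or a longer alkoxy chain on this aryl ring holds the number near compound 1 remains open.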